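A few compounds are considered here, and "the series" means these few. Any claim that something is new, unique, unknown or untested is made for them only; others in the source may bear on it.

For the measured compounds named here, compound 2 `CCCCCc1ccc(C#Cc2cn(C/C=C/CN3C(=O)c4ccccc4C3=O)c(=O)[nH]c2=O)cc1` gives 5600 nM in a functional assay on MCF7 cells (Homo sapiens) for antiproliferative activity, read by MTT assay, with a stated time of 3 days (on this read-out higher numbers stand for weaker inhibition and lower numbers for stronger inhibition), the lower of the two numbers measured so far. Going by the values given here, compound 1 `O=C1c2ccccc2C(=O)N1C/C=C/Cn1cc(C#CCCc2ccccc2)c(=O)[nH]c1=O` gives 13000 nM in this assay, and the one step measured, a 2.3-fold lower number from compound 1 to compound 2 (0.37 log units; beyond the scatter), bears on the change now considered. Compound 3 `CCCCCCCCC#Cc1cn(C/C=C/CN2C(=O)c3ccccc3C2=O)c(=O)[nH]c1=O` differs from compound 2 by octyl in place of 4-pentylphenyl on a triple-bonded carbon. That earlier step only hints that a longer chain-bearing group was tolerated, so little change beyond the scatter is expected here, if anything a slightly higher number. For compound 3 the estimate in this assay is 8000 nM, within 3000 nM to 25000 nM, expected as a step of a 1.4-fold higher number from compound 2 to compound 3 (0.15 log units; within the scatter).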

Compound 3, half-maximal inhibitory concentration: 66000 nM
Compound 3: middle estimate off by 8.3-fold (0.92 log units), on the low side; measured number above the stated range.
By their numbers in this assay, from the lowest: compound 2; then compound 1; then compound 3.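

In this assay, octyl in place of 4-pentylphenyl on a triple-bonded carbon gives a 12-fold higher number from compound 2 to compound 3 (1.07 log units; beyond the scatter), so this position is far less forgiving than the earlier step suggested. Hexyl in place of phenyl on a saturated chain carbon gives a 5.1-fold higher number from compound 1 to compound 3 (0.71 log units; beyond the scatter), and among these three compounds, the two carrying a six-membered aromatic ring give lower numbers than the one with no ring. Nothing measured here explains this difference. Still open, as far as these compounds go, is whether a plain phenyl, or a phenyl carrying an amine or a carboxylic acid, would keep the lower numbers.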